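From 4-methylphenyl to 4-fluorophenyl: an open step

The source may hold more compounds than are shown below. What is called first, only, known or untested is meant among the compounds shown, and "the series" means these compounds.

For the measured compounds named here, in a functional assay on HL-60 cells (Homo sapiens) for antiproliferative activity, read by sulforhodamine B assay, with a stated time of 72 h (a lower number here means a stronger inhibitor, a higher number a weaker inhibitor), compound 3 `Cc1ccc(NC(=S)N/N=C/c2ccc3ccccc3n2)cc1` gives 78300 nM, the higher of the two exact numbers so far. The other exact number comes from compound 2 `N#Cc1ccc(NC(=S)N/N=C/c2ccc3ccccc3n2)cc1`, at 4660 nM. Compound 1 `NC(=S)N/N=C/c1cc2cccnc2s1` gives > 100000 nM, which is a limit of the assay. Compound 4 `Fc1ccc(NC(=S)N/N=C/c2ccc3ccccc3n2)cc1` changes one group of compound 3: fluoro in place of methyl on an aromatic carbon. Going by the values given here, one measured step touches this place, the large 17-fold higher number from compound 2 to compound 3 (1.23 log units; beyond the scatter), where methyl replaced cyano. Fluoro itself is untested, so a smaller move toward a lower number in this assay is expected. The expected move is a 2.6-fold lower number from compound 3 to compound 4 (0.42 log units; beyond the scatter). For compound 4 the estimated value is 30000 nM, with a range of 8000 nM to 90000 nM.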

Compound 4, half-maximal inhibitory concentration: 17000 nM
For compound 4 the middle estimate is 1.8-fold (0.25 log units) above the measured one, within the range that was stated.
By their numbers in this assay, from the lowest: compound 2; then compound 4; then compound 3. At a limit, above all of these: compound 1.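

In this assay, the position para to a large group now holds a third group, and fluoro lands between the other two. Fluoro beats methyl, a 4.6-fold lower number from compound 3 to compound 4 (0.66 log units; beyond the scatter), but falls short of cyano, a 3.6-fold higher number from compound 2 to compound 4 (0.56 log units; beyond the scatter), so the order from the lowest number up is cyano, fluoro, methyl. Nothing measured here explains why the groups rank this way. On these data alone, whether an amine or a carboxylic acid at this place would give a lower number than cyano stays open.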